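Stripping the Sulfur-Linked Group from Compound 2

The compounds below may be only part of what the source reports. "The series", "measured", "known", "first", "only" and "open" are said of these compounds alone.

- compound 1 `Cc1cc(Nc2cc(-c3ccccc3)[nH]n2)n2nc(SCCCc3ccccc3)nc2n1`: 3900 nM
- compound 2 `Cc1cc(Nc2cc(-c3ccccc3)[nH]n2)n2nc(SCc3nc4ccccc4[nH]3)nc2n1`: 2730 nM

Both compounds were tested in a functional assay on MCF7 cells (Homo sapiens) for inhibition, read by MTT assay, with a stated time of 72 h; on this read-out lower numbers stand for stronger inhibition and higher numbers for weaker inhibition. There, compound 2 gives 2730 nM and compound 1 gives 3900 nM, so the two stand within the scatter of each other and neither can be ranked above the other.

Compound 3 `Cc1cc(Nc2cc(-c3ccccc3)[nH]n2)n2ncnc2n1` carries hydrogen in place of ((1H-benzimidazol-2-yl)methyl)sulfanyl on an aromatic carbon. Among the compounds with values here, only one measured step bears on this change: a 1.4-fold lower number from compound 1 to compound 2 (0.15 log units; within the scatter). That step swaps one group on the sulfur for another, and the number barely moves. Within the data shown here, it shows that these two groups give similar values, but it does not show what happens with no such group at all, since no measured compound lacks one. The change here is far larger than a swap, so a step beyond the scatter is reasonable to expect in this assay, towards weaker inhibition, though with much uncertainty. The expected step is a 3.3-fold higher number from compound 2 to compound 3 (0.52 log units; beyond the scatter). For compound 3 the estimated value is 9000 nM, with an expected range from 2500 nM to 35000 nM.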

Compound 3, half-maximal inhibitory concentration: > 50000 nM
Compound 3 was reported as a limit; the forecaster's own chance of this, stated with the estimate: 20%; at least 5.5-fold (0.74 log units) between middle value and limit.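

Swapping one group on the sulfur for another had left the number within the scatter, but removing the sulfur-linked group altogether has a far larger effect. Hydrogen in place of ((1H-benzimidazol-2-yl)methyl)sulfanyl gives an at least 18-fold higher number from compound 2 to compound 3 (1.26 log units; beyond the scatter), and hydrogen in place of (3-phenylpropyl)sulfanyl gives an at least 12-fold higher number from compound 1 to compound 3 (1.10 log units; beyond the scatter). Both steps point the same way, so among these three compounds, a sulfur-linked group on this aromatic carbon goes with a measurable number in this assay, while hydrogen there gives only a limit: the limit of > 50000 nM in this assay, at which 1 of the 3 values shown sits.

What remains open is how much of the sulfur-linked group this position needs, since both groups shown pair the sulfur with a carbon chain ending in an aromatic ring. A small methylsulfanyl group would test whether the sulfur with a single carbon is enough, and an amine on the same carbon would test whether sulfur is needed at all.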